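A few compounds are considered here, and "the series" means these few. Any claim that something is new, unique, unknown or untested is made for them only; others in the source may bear on it.

Working notes on the series. Compound 1 `CCCCCCN1C(=O)[C@H](Cc2ccc(-c3cc(OC)c(OC)c(OC)c3)cc2)N(C)C(=O)[C@@H]1C` in a functional assay for agonist activity at follicle-stimulating hormone receptor (Homo sapiens), read by a luciferase reporter (on this read-out lower numbers stand for an effect already at smaller amounts and higher numbers for an effect only at larger amounts of compound), gives 100 nM; compound 2 `CCCCCCCCN1C(=O)[C@H](Cc2ccc(-c3cc(OC)c(OC)c(OC)c3)cc2)N(C)C(=O)[C@@H]1C` in this assay gives 13 nM. The change between them, (ethyl in place of hydrogen on a saturated chain carbon, six bonds along the chain from an amide-type nitrogen in a ring), produced a 7.7-fold lower number from compound 1 to compound 2 (0.89 log units; beyond the scatter). Compound 3 `CCCCCCN1C(=O)[C@H](Cc2ccc(-c3cccc(CN(CCCC)C(C)=O)c3)cc2)N(C)C(=O)[C@@H]1C` carries a different core; the difference between the two cores is not broken down here. In this assay compound 3 gives 150 nM. Compound 4 `CCCCCCCCN1C(=O)[C@H](Cc2ccc(-c3cccc(CN(CCCC)C(C)=O)c3)cc2)N(C)C(=O)[C@@H]1C`, not yet measured, differs from compound 3 by ethyl in place of hydrogen on a saturated chain carbon, six bonds along the chain from an amide-type nitrogen in a ring, the same change as between compound 1 and compound 2, at the same place. A step of a similar size is therefore expected, a 6.0-fold lower number from compound 3 to compound 4 (0.78 log units; beyond the scatter), resting on the single earlier case, compound 1 to compound 2, a 7.7-fold lower number from compound 1 to compound 2 (0.89 log units; beyond the scatter); with one precedent only, a wider range is allowed. Compound 4 is estimated at 25 nM, expected between 8 nM and 80 nM.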

Compound 4, half-maximal effective concentration: 14 nM
Compound 4: the middle estimate sits 1.8-fold (0.25 log units) above what was measured, and the stated range covers the measured number.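

Ethyl in place of hydrogen on this saturated chain carbon also lowered the number on the second core in this assay, with an 11-fold lower number from compound 3 to compound 4 (1.03 log units; beyond the scatter). Set beside the earlier case, the two steps do not differ: the same change on two cores in this assay, a 7.7-fold lower number (0.89 log units; beyond the scatter) from compound 1 to compound 2 and an 11-fold lower number (1.03 log units; beyond the scatter) from compound 3 to compound 4, 1.4-fold (0.14 log units) apart, within the scatter of two such steps. This shows that the step kept its size on these two cores in this one read-out, but it does not show that the step would keep its size on other cores, nor does it explain why the size holds.

As far as these compounds go, whether a longer chain, or a chain ending in an amine or a carboxylic acid, would give a lower or a higher number remains open. From the compounds shown here alone, the size of the step on any further core also remains open.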